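The source may report more compounds than this note shows. Statements on the series, on what has been measured and on what is new or still open speak of the compounds shown alone.

Of the compounds shown here, two sharing a core have been tested in a functional assay on A549 cells (Homo sapiens) for cytotoxicity, read by crystal violet staining, with a stated time of 3 days; a lower number here means a stronger inhibitor, a higher number a weaker inhibitor: compound 1 `COc1cc2c(cc1OC)C(/C(C)=N/NC(N)=S)N(S(=O)(=O)c1ccc(C)cc1)CC2` and compound 2 `C/C(=N\NC(N)=S)C1c2ccccc2CCN1S(=O)(=O)c1ccc([N+](=O)[O-])cc1`. Compound 1 gives > 50 ug/mL, which is a limit of the assay and not a number. Compound 2 gives > 50 ug/mL, again only a limit. Compound 2 therefore stands with compound 1 at the limit of > 50 ug/mL in this assay, at which 2 of the 2 values shown sit, and no measured number places either of them more exactly. Compound 3 `C/C(=N\NC(N)=S)C1c2ccccc2CCN1S(=O)(=O)c1cccc([N+](=O)[O-])c1` has the same atoms as compound 2, joined differently, with 3-nitrophenyl in place of 4-nitrophenyl on a sulfonyl sulfur. Since compound 2 rests at the limit of > 50 ug/mL, compound 3 is expected to remain weak in this assay. The estimated change a number no higher from compound 2 to compound 3 (the limit leaves the size open) is expected to stay within the usual scatter. The expected value for compound 3 is 50 ug/mL, with an estimated range from 15 ug/mL to 100 ug/mL.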

Compound 3, half-maximal inhibitory concentration: > 50 ug/mL
Compound 3: only a limit was reported; the forecaster's own chance of this, stated with the estimate: 70%; the middle value lies on the limit itself.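

Compound 2 and compound 3 each give only a limit and not a number, so no step can be read between them: the limit of > 50 ug/mL in this assay, at which 3 of the 3 values shown sit.

From the compounds shown here alone, how strongly any of the three compounds acts on these cells, and whether 3-nitrophenyl and 4-nitrophenyl differ at all, stays open.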